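This account rests on a few compounds, and the source may have more. Where it says the series, first, only, none or still open, it means among the compounds named here.

Two members of the series have been through an ADME assay on Huh-7 cells (Homo sapiens) for cytotoxicity (a lower number here means that less compound is tolerated, a higher number that more compound is tolerated), so far. Compound 1, `O=C(NC(=S)n1ccc2c(OCCCCCOc3ccc(Cl)cc3)cccc21)c1ccccc1`, gives 29500 nM in this assay. Compound 2, `O=C(NC(=S)N1CCc2c(OCCCCCOc3ccc(Cl)cc3)cccc21)c1ccc(F)cc1`, gives 31100 nM and stands as the higher of the two numbers, though its gap to compound 1 lies within the usual scatter, so the two are not distinguished here. Among the compounds with values here, no single-point step between measured compounds is available, and nothing in the measured pair speaks to the change that leads to compound 3, `CN(C)c1ccc(C(=O)NC(=S)N2CCc3c(OCCCCCOc4ccc(Cl)cc4)cccc32)cc1`. The change is dimethylamino in place of fluoro on an aromatic carbon. Within the data shown here, with no comparable step to rest on, the expectation from compound 2 to compound 3 in this assay is a step no larger than the scatter, a 1.2-fold lower number from compound 2 to compound 3 (0.08 log units; within the scatter), in no preferred direction. Compound 3 is therefore estimated at 26000 nM, with a range from 10000 nM to 65000 nM.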

Compound 3, half-maximal cytotoxic concentration: > 50000 nM
Compound 3: a limit, no number; the forecaster's own chance of this, stated with the estimate: 15%; middle value at least 1.9-fold (0.28 log units) away from the limit.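

In this assay, within the data shown here, the first single-point reading at this position is the change from 4-fluorophenyl to 4-(dimethylamino)phenyl, which gives an at least 1.6-fold higher number from compound 2 to compound 3 (0.20 log units; that floor lies within the scatter). The aromatic carbon para to a large group therefore takes dimethylamino, with its three heavy atoms and one hydrogen-bond acceptor, without a lower number than fluoro gives. The true size of the step stays unknown, and it cannot be said to exceed the scatter, because the result for compound 3 is a limit and not a number: the limit of > 50000 nM in this assay, at which 1 of the 3 values shown sits.

From the compounds shown here alone, whether a smaller amine such as methylamino, or a carboxylic acid, on this carbon would also reach the limit stays open. Also open, going by these compounds, is whether dimethylamino gives the same reading on the core of compound 1.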